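From Chloro to Benzyl on the Shared Core

The source may hold more compounds than are shown below. What is called first, only, known or untested is meant among the compounds shown, and "the series" means these compounds.

In a functional assay on HL-60 cells (Homo sapiens) for cytotoxicity, read by luminescence and CellTiter-Glo, with a stated time of 3 days (on this read-out higher numbers stand for weaker inhibition and lower numbers for stronger inhibition), compound 3 (`N#Cc1ccc(NC(=O)c2cc(Cl)ccc2O)cc1`) gives 700 nM and holds the lowest of three numbers, against compound 1 (`N#Cc1ccc(NC(=O)c2cc(-c3ccncc3)ccc2O)cc1`) at 5410 nM and compound 2 (`N#Cc1ccc(NC(=O)c2cc(-c3cccnc3)ccc2O)cc1`) at 7960 nM in the same test. Compound 4 (`N#Cc1ccc(NC(=O)c2cc(Cc3ccccc3)ccc2O)cc1`) carries benzyl in place of chloro on an aromatic carbon. The nearest evidence is a 7.7-fold lower number from compound 1 to compound 3 (0.89 log units; beyond the scatter) and an 11-fold lower number from compound 2 to compound 3 (1.06 log units; beyond the scatter) when chloro replaced a pyridinyl group, while a 1.5-fold higher number from compound 1 to compound 2 (0.17 log units; within the scatter) between the two pyridinyl groups. Going by the values given here, no measured compound carries benzyl, so those steps are only a rough guide, read in reverse. The expected change is a 3.6-fold higher number from compound 3 to compound 4 (0.55 log units; beyond the scatter) in this assay as a moderate rise. Compound 4 is estimated at 2500 nM with 800 nM to 7000 nM as the expected range.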

Compound 4, half-maximal inhibitory concentration: 1740 nM
Compound 4: the middle estimate sits 1.4-fold (0.16 log units) above what was measured, and the stated range covers the measured number.
By their numbers in this assay, from the lowest: compound 3; then compound 4; then compounds 1 and 2 (each within the scatter of the next).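

In this assay benzyl, para to a hydroxy group, lies under both pyridinyl groups, with a 4.6-fold lower number from compound 2 to compound 4 (0.66 log units; beyond the scatter) and a 3.1-fold lower number from compound 1 to compound 4 (0.49 log units; beyond the scatter) on this one change, so a ring-bearing group here need not cost as much as those two did. Chloro still keeps the lowest number, with a 2.5-fold higher number from compound 3 to compound 4 (0.40 log units; beyond the scatter) when benzyl takes its place, so the larger group does not match it. Nothing shown gives a reason for these steps. The compounds shown leave open how a phenyl group, a methoxy group or an amine would read at this place.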